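The source may report more compounds than this note shows. Statements on the series, on what has been measured and on what is new or still open speak of the compounds shown alone.

Measured compounds:
- compound 1, `COc1ccc(-c2cn(C/C=C3\OC(=O)C(OCc4ccccc4)=C3OCc3ccccc3)nn2)cc1`, 39100 nM
- compound 2, `Cc1ccc(S(=O)(=O)NCc2cn(C[C@H](O)[C@H]3OC(=O)C(OCc4ccccc4)=C3OCc3ccccc3)nn2)cc1`, 6400 nM

Two compounds sharing the same core have been run in a functional assay on MCF7 cells (Homo sapiens) for antiproliferative activity, read by MTT assay, with a stated time of 72 h; a higher number here means a weaker inhibitor, a lower number a stronger inhibitor. Compound 1 gives 39100 nM, while compound 2 gives 6400 nM. Compound 2 therefore stands as the lower of the two numbers, and the gap to compound 1 lies beyond the usual scatter of this assay. The two differ in more than one place, so no single change can be credited with that gap.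

Compound 3, `O=C1O[C@H]([C@@H](O)Cn2cc(-c3ccc(Br)cc3)nn2)C(OCc2ccccc2)=C1OCc1ccccc1`, has not yet been measured. It differs from compound 2 in one place: 4-bromophenyl in place of (((4-methylphenyl)sulfonyl)amino)methyl on an aromatic carbon. The hydroxyl-bearing linker of compound 2 is kept; only the group on the five-membered ring changes.

Since the arylated analogue compound 1 shows the higher value 39100 nM, the expectation is a shift toward weaker inhibition for compound 3, modest in size, as a 2.3-fold higher number from compound 2 to compound 3 (0.37 log units; beyond the scatter). The estimate for compound 3 in this assay is 15000 nM, within a range of 4000 nM to 60000 nM.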

Compound 3, half-maximal inhibitory concentration: 5620 nM
The estimate for compound 3 lay 2.7-fold (0.43 log units) above the measured number; the range from low to high includes it.
By their numbers in this assay, from the lowest: compounds 3 and 2 (each within the scatter of the next); then compound 1.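

In this assay the exchange on this aromatic carbon gives a 1.1-fold lower number from compound 2 to compound 3 (0.06 log units; within the scatter), so the two groups cannot be told apart at this position while the hydroxyl-bearing linker is kept. This holds although the change is a large one in structure: the (((4-methylphenyl)sulfonyl)amino)methyl group has 12 heavy atoms, 1 hydrogen-bond donor and 2 hydrogen-bond acceptors, whereas the 4-bromophenyl group has 7 heavy atoms and neither donors nor acceptors, and the sulfonyl and amino parts can go without any change beyond the scatter. No measurement at hand accounts for this result.

Going by these compounds, both groups carry a six-membered aromatic ring of carbon only, so it remains open whether the position would accept something without such a ring, such as an amine, a carboxylic acid or a longer chain, with equally little change. Also open, on these data alone, is what the bromine itself contributes, which a plain phenyl group or a chlorine in its place on the ring would begin to show.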